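Swapping the Ether for Chlorine on the Shared Core

A few compounds are considered here, and "the series" means these few. Any claim that something is new, unique, unknown or untested is made for them only; others in the source may bear on it.

Measured compounds and their values:
Compound 1, `O=C(O)CCn1c(=O)oc2cc(OCc3ccccc3)c(Cl)cc21`, gives 1580 nM in an assay on HEK293 cells for inhibition of kynurenine 3-monooxygenase (Homo sapiens), read by LC-MS, with a stated time of 20 h; on this read-out lower numbers stand for stronger inhibition and higher numbers for weaker inhibition.
Compound 2, `CCOc1cc2oc(=O)n(CCC(=O)O)c2cc1Cl`, gives 398 nM.
Compound 3, `O=C(O)CCn1c(=O)oc2cc(OCC3CC3)c(Cl)cc21`, gives 1580 nM.

Compound 3 stands level with compound 1 at the digits shown, and together they carry the highest numbers of the three; compound 2 sits apart from compound 3 by a 4.0-fold higher number from compound 2 to compound 3 (0.60 log units; beyond the scatter).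

Compound 4, `O=C(O)CCn1c(=O)oc2cc(Cl)c(Cl)cc21`, differs from compound 3 in one place: chloro in place of cyclopropylmethoxy on an aromatic carbon. Every measured step here changes only the group on a saturated chain carbon bound to an oxygen on the aromatic ring: a 4.0-fold lower number from compound 1 to compound 2 (0.60 log units; beyond the scatter), no change at the digits printed from compound 1 to compound 3 (within the scatter), and a 4.0-fold higher number from compound 2 to compound 3 (0.60 log units; beyond the scatter). The step to compound 4 removes that oxygen entirely and puts a chloro group on the aromatic carbon, so none of these steps bears on it directly. For the measured compounds named here, they show only that this position tolerates changes within a modest range.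

Going by the values given here, with no closer precedent, the expectation for compound 4 is a step of a 2.0-fold lower number from compound 3 to compound 4 (0.30 log units; within the scatter), with wide uncertainty. Compound 4 is estimated at 800 nM, between 250 nM and 3000 nM.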

Compound 4, half-maximal inhibitory concentration in the kynurenine 3-monooxygenase assay: 2000 nM
Beside the measured number, compound 4's estimate is 2.5-fold (0.40 log units) below it; the range from low to high includes it.
By their numbers in the kynurenine 3-monooxygenase assay, from the lowest: compound 2; then compounds 1, 3 and 4 (each within the scatter of the next).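

In the kynurenine 3-monooxygenase assay, a chloro group with no ether oxygen sits within the scatter of both larger ethers, at a 1.3-fold higher number from compound 3 to compound 4 (0.10 log units; within the scatter) and a 1.3-fold higher number from compound 1 to compound 4 (0.10 log units; within the scatter), while the ethoxy group of compound 2 stays apart, with a 5.0-fold higher number from compound 2 to compound 4 (0.70 log units; beyond the scatter). In a physicochemical assay for solubility, with a stated time of 24 h (a lower number here means a less soluble compound, a higher number a more soluble compound), compound 3 gives > 2060 ug/mL, which is a limit of the assay and not a number. In the physicochemical assay, compound 4 gives 270 ug/mL, so this change comes with an at least 7.6-fold lower number from compound 3 to compound 4 (0.88 log units; beyond the scatter), a size that is only a minimum: the limit of > 2060 ug/mL in the physicochemical assay, at which 1 of the 2 values shown sits.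

On these data alone, whether a methoxy group or an amine on this aromatic carbon would match the ethoxy group in the kynurenine 3-monooxygenase assay remains open. Also open, as far as these compounds go, is how such a group would compare with chloro and cyclopropylmethoxy in the physicochemical assay.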